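A few compounds are considered here, and "the series" means these few. Any claim that something is new, unique, unknown or untested is made for them only; others in the source may bear on it.

In a functional assay on MCF7 cells (Homo sapiens) for antiproliferative activity, read by sulforhodamine B assay, with a stated time of 48 h (on this read-out lower numbers stand for stronger inhibition and higher numbers for weaker inhibition), two compounds built on the same core have been measured so far: compound 1 `CO/N=C1/C(=O)N(CCCCCCC(=O)NO)c2ccc(F)cc21` gives 2420 nM and compound 2 `CO/N=C1/C(=O)N(CCCCCCC(=O)NO)c2ccc(Cl)cc21` gives 1560 nM. Within the data shown here, these two values lie within the scatter of each other, so the numbers do not set compound 2 apart from its only measured neighbour. Compound 3 `CO/N=C1/C(=O)N(CCCCCCC(=O)NO)c2ccc(Br)cc21` awaits measurement and differs from compound 2 by a single change: bromo in place of chloro on an aromatic carbon, in words bromo in place of chloro on an aromatic carbon. Among the measured compounds shown here, the one measured step that bears on this change is chloro in place of fluoro at the same place, a 1.6-fold lower number from compound 1 to compound 2 (0.19 log units; within the scatter), which lies within the scatter. Going by that step, no change beyond the scatter and no particular direction is expected in this assay. The expected step is a 1.1-fold lower number from compound 2 to compound 3 (0.05 log units; within the scatter). Compound 3 is estimated at 1400 nM, with an expected range from 700 nM to 2900 nM.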

Compound 3, half-maximal inhibitory concentration: 7790 nM
For compound 3 the middle estimate is 5.6-fold (0.75 log units) below the measured one; measured number outside the range, above it.
By their numbers in this assay, from the lowest: compounds 2 and 1 (each within the scatter of the next); then compound 3.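

Bromo in place of chloro gives a 5.0-fold higher number from compound 2 to compound 3 (0.70 log units; beyond the scatter) and bromo in place of fluoro gives a 3.2-fold higher number from compound 1 to compound 3 (0.51 log units; beyond the scatter) in this assay. This aromatic carbon is therefore not indifferent to which halogen it carries, since an exchange of one halogen for another can move the number beyond the scatter, something compound 1 and compound 2 alone did not show. No measurement at hand accounts for the size of this step or for its appearance with bromo.

The compounds shown leave open whether the higher number is particular to bromo or would also come with another group at this place, such as iodo, methyl, methoxy or nitrile, or with plain hydrogen. They also leave open whether the same step would hold on the shared core with a shorter or longer chain.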